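The source may report more compounds than this note shows. Statements on the series, on what has been measured and on what is new or still open speak of the compounds shown alone.

Compound 1 `N#CC1=C(NC(=O)C2CC2)N(c2ccc(S(N)(=O)=O)cc2)C2=C(C(=O)CCC2)C1c1ccc(Cl)cc1Cl`: 60%
Compound 2 `N#CC1=C(NC(=O)c2ccccc2)N(c2ccc(S(N)(=O)=O)cc2)C2=C(C(=O)CCC2)C1c1ccc(Cl)cc1Cl`: 75%
Compound 3 `N#CC1=C(NC(=O)/C=C/c2ccccc2)N(c2ccc(S(N)(=O)=O)cc2)C2=C(C(=O)CCC2)C1c1ccc(Cl)cc1Cl`: 45%

All three share one core and differ only in the group on the amide carbonyl carbon. In a functional assay on Ehrlich cells (Mus musculus) for cytotoxicity, read by trypan blue exclusion, with a stated time of 2 h, tested at 100 ug/mL (on this read-out higher numbers stand for a stronger effect at the one concentration tested and lower numbers for a weaker effect), compound 3 stands lowest of the three; its nearest neighbour is compound 1, and compound 2 is furthest away, both steps being beyond the scatter.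

Compound 4 `COc1cc(C(=O)NC2=C(C#N)C(c3ccc(Cl)cc3Cl)C3=C(CCCC3=O)N2c2ccc(S(N)(=O)=O)cc2)cc(OC)c1OC` carries the change (3,4,5-trimethoxyphenyl in place of 2-phenylethenyl on a carbonyl carbon). Going by the values given here, the steps that bear on it are a number 30 percentage points lower from compound 2 to compound 3 (beyond the scatter), a number 15 percentage points higher from compound 1 to compound 2 (beyond the scatter) and a number 15 percentage points lower from compound 1 to compound 3 (beyond the scatter); an aromatic ring on the carbonyl carbon has so far given the highest number, the phenylethenyl the lowest. Going back from phenylethenyl to an aromatic ring is therefore expected to raise this assay by a modest amount, roughly a number 20 percentage points higher from compound 3 to compound 4 (beyond the scatter). For compound 4 the expected value is 65%, in the range 40% to 85%.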

Compound 4, a percentage reported as activity, at one concentration (the size of the read-out at that concentration, not a potency): 95%
Compound 4: middle estimate off by 30 percentage points, on the low side, and the stated range ends below it.
By their numbers in this assay, from the lowest: compound 3; then compound 1; then compound 2; then compound 4.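

In this assay unsubstituted phenyl does not set the upper end at this carbonyl carbon: 3,4,5-trimethoxyphenyl gives a number 20 percentage points higher from compound 2 to compound 4 (beyond the scatter) and stands highest of the four. The change is larger against the other two groups, with a number 50 percentage points higher from compound 3 to compound 4 (beyond the scatter) and a number 35 percentage points higher from compound 1 to compound 4 (beyond the scatter) in the same direction. No measurement available here accounts for the gain.

As far as these compounds go, whether all three methoxy groups are needed remains open. So does how a phenyl ring carrying a single methoxy group, a hydroxy group or an amine would read at this carbonyl carbon.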